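Silyl cyanohydrins against phenylethanolamine N-methyltransferase: a working note

The source may report more compounds than this note shows. Statements on the series, on what has been measured and on what is new or still open speak of the compounds shown alone.

Measured compounds:
compound 1 `C[Si](C)(C)OC(C#N)C1CCC1` — > 1000000 nM
compound 2 `CCCCC(O)CN` — 345000 nM
compound 3 `NCC1(O)CCCCCCC1` — 72000 nM

In an assay on isolated protein for inhibition of Phenylethanolamine N-methyltransferase (Bos taurus) (a higher number here means a weaker inhibitor, a lower number a stronger inhibitor), compound 1 returns only a limit, > 1000000 nM. Compound 2 gives 345000 nM in this assay, and compound 3 gives 72000 nM. Among the measured compounds shown here, compound 1 is the one compound of the three that sits at the limit (the limit of > 1000000 nM in this assay, at which 1 of the 3 values shown sits); the two amino alcohols, compound 2 and compound 3, each give a number, so within this small set compound 1 stands at the weak end of what the assay can report.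

Compound 4 `CC(C)CC(C#N)O[Si](C)(C)C` is not yet measured. It differs from compound 1 by one change: isobutyl in place of cyclobutyl on a saturated chain carbon bound to an oxygen and a triple-bonded carbon. For the measured compounds named here, no measured pair in the set shows what such a swap does. The silyl ether and nitrile of compound 1 are kept, and compound 1 already lies at the limit, so no step beyond the scatter is expected in this assay; the expected step that the limit leaves unreadable from compound 1 to compound 4 is essentially flat. Compound 4 is therefore estimated at 1500000 nM, with a range of 300000 nM to 8000000 nM, and most likely the assay will again report only a limit.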

Compound 4, half-maximal inhibitory concentration: 1000000 nM
Estimate against measurement, compound 4: 1.5-fold (0.18 log units) above; the measured number falls inside the stated range.
By their numbers in this assay, from the lowest: compound 3; then compound 2; then compound 4.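

In this assay, isobutyl in place of cyclobutyl on a saturated chain carbon bound to an oxygen and a triple-bonded carbon gives a number no higher from compound 1 to compound 4 (the limit leaves the size open). With the silyl ether and nitrile kept, compound 4 gives 1000000 nM, so this change at this place yields a plain number, which compound 1 does not provide. Compound 1 remains a limit, > 1000000 nM, and the size of the step cannot be read: the limit of > 1000000 nM in this assay, at which 1 of the 4 values shown sits.

The compounds shown leave open what an amine in place of the nitrile would do with the silyl ether kept, and whether a longer chain in place of isobutyl would move the value away from that of compound 4. Among the compounds shown here, no pair differing in one place yet links this silyl ether pair to the amino alcohols, compound 2 and compound 3.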